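The source may hold more compounds than are shown below. What is called first, only, known or untested is meant among the compounds shown, and "the series" means these compounds.

Of the compounds shown here, three have so far been measured in a functional assay on NCI-H1975 cells (Homo sapiens) for antiproliferative activity, read by CCK-8 assay, with a stated time of 72 h; a higher number here means a weaker inhibitor of growth, a lower number a stronger inhibitor of growth. Compound 1 `CCC1C(=O)N(C)c2cnc(Nc3ccc(S(=O)(=O)NCC(C)C)cc3)nc2N1c1ccn(C)n1` gives 15000 nM in this assay. Compound 3 `CCC1C(=O)N(C)c2cnc(-n3ccc4cc(C(=O)NC(C)C)ccc43)nc2N1c1ccn(C)n1` gives 12200 nM in this assay. Compound 2 `CC[C@@H]1C(=O)N(C)c2cnc(-n3ccc4cc(C(=O)NC(C)C)ccc43)nc2N1C1CCCC1` gives 1840 nM in this assay, the lowest of the three numbers, so compound 2 is the strongest growth inhibitor of the set: compound 3 is its nearest neighbour and compound 1 lies furthest away, and both gaps are beyond the usual scatter of repeated measurements.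

The unmeasured compound 4 `CC[C@@H]1C(=O)N(C)c2cnc(-n3ccc4cc(C(N)=O)ccc43)nc2N1C1CCCC1` is compound 2 with a single change: hydrogen in place of isopropyl on an amide-type nitrogen. The isopropyl group leaves and only a hydrogen remains on the amide-type nitrogen, whose other neighbour is the carbonyl carbon. For the measured compounds named here, no measured pair in this set shows this same change, so nothing here tells directly how large its effect is. The expected step of a 1.9-fold higher number from compound 2 to compound 4 (0.28 log units; within the scatter) is a modest rise in the number, that is a somewhat weaker inhibitor, close to the edge of the scatter. Compound 4 is therefore expected to give about 3500 nM in this assay, with a likely range from 1200 nM to 10000 nM.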

Compound 4, concentration for 50% growth inhibition: 3380 nM
Compound 4: the middle estimate sits 1.0-fold (0.02 log units) above what was measured; the range from low to high includes it.
By their numbers in this assay, from the lowest: compounds 2 and 4 (each within the scatter of the next); then compounds 3 and 1 (each within the scatter of the next).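

In this assay, replacing isopropyl with hydrogen on the amide-type nitrogen gives a 1.8-fold higher number from compound 2 to compound 4 (0.26 log units; within the scatter), so the two compounds cannot be told apart. For the compounds shown here, this is the first pair in the set that differs in this one place, and it shows that, on this scaffold, growth inhibition in this assay holds within the scatter without the isopropyl group: the carbamoyl group does as well here as the isopropylcarbamoyl group. No measured evidence is available to explain this result.

Going by these compounds alone, a single pair tests only one substituent swap, so it gives no trend for this nitrogen. On these data alone, whether a longer chain, such as n-butyl, or a cyclopropyl ring on that nitrogen, or a carboxylic acid in place of the whole amide, would move the number beyond the scatter remains open.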